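Same atoms, rearranged chain: what to expect for compound 3

The source may hold more compounds than are shown below. What is called first, only, known or untested is meant among the compounds shown, and "the series" means these compounds.

Measured in a functional assay on HT-29 cells (Homo sapiens); on this read-out higher numbers stand for an effect only at larger amounts of compound and lower numbers for an effect already at smaller amounts:
- compound 1 `CN(CCN)C(=O)c1cc(-c2ccccc2)sc1NC(N)=O`: "not determined" (no result reported)
- compound 2 `CS(=O)(=O)Nc1ccc(-c2cc(C(=O)N[C@H]3CCCNC3)c(NC(N)=O)s2)cc1`: 2200 nM

Compound 1 has no single number to stand on, since its entry reads "not determined" (no result reported). Compound 3 `CNCCNC(=O)c1cc(-c2ccccc2)sc1NC(N)=O` has the same atoms as compound 1, joined differently: (2-(methylamino)ethyl)amino in place of (2-aminoethyl)(methyl)amino on a carbonyl carbon. Here (2-(methylamino)ethyl)amino takes the place of (2-aminoethyl)(methyl)amino on a carbonyl carbon. Going by the values given here, no measured pair shows what such a change does in this assay, so no step beyond the scatter is expected, in either direction. Among the compounds with values here, the only number nearby is that of compound 2 at 2200 nM, a compound that differs in more than one place. Compound 3 is expected near 4000 nM, with an estimated range of 800 nM to 20000 nM.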

Compound 3, half-maximal effective concentration: 580 nM
Estimate against measurement, compound 3: 6.9-fold (0.84 log units) above; the whole stated range lies above it.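

Going by these compounds alone, compound 1 has no number in this assay, so no step from it to compound 3 can be read. Going by these compounds, what replacing (2-aminoethyl)(methyl)amino with (2-(methylamino)ethyl)amino does to the effect stays open. No evidence shown bears on this result.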